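Restoring a methoxy group on the benzyl side

The source may report more compounds than this note shows. Statements on the series, on what has been measured and on what is new or still open speak of the compounds shown alone.

Compound 1 `COc1ccc(CN(C(=O)CSc2nc3ccccc3s2)c2cc(OC)c(OC)c(OC)c2)cc1C`: 17100 nM
Compound 2 `COc1cc(N(Cc2ccccc2)C(=O)CSc2nc3ccccc3s2)cc(OC)c1OC`: 54500 nM
Compound 3 `COc1cc(N(Cc2ccc(Cl)cc2)C(=O)CSc2nc3ccccc3s2)cc(OC)c1OC`: 603000 nM

These values come from a functional assay on HCT-116 cells (Homo sapiens) for antiproliferative activity, read by MTT assay, with a stated time of 48 h (a higher number here means a weaker inhibitor, a lower number a stronger inhibitor), where compound 3 has the highest number of the three. In compound 4 `COc1ccc(CN(C(=O)CSc2nc3ccccc3s2)c2cc(OC)c(OC)c(OC)c2)cc1F`, 3-fluoro-4-methoxyphenyl stands in place of 4-chlorophenyl on a saturated chain carbon bound to an amide-type nitrogen (3-fluoro-4-methoxyphenyl in place of 4-chlorophenyl on a saturated chain carbon bound to an amide-type nitrogen). Two large steps bear on this change, a 35-fold higher number from compound 1 to compound 3 (1.55 log units; beyond the scatter) and an 11-fold higher number from compound 2 to compound 3 (1.04 log units; beyond the scatter), while the step of a 3.2-fold higher number from compound 1 to compound 2 (0.50 log units; beyond the scatter) is modest. The entering group shares its methoxy with the 4-methoxy-3-methylphenyl of compound 1, so a large step towards a lower number is expected in this assay. The expected change is a 24-fold lower number from compound 3 to compound 4 (1.38 log units; beyond the scatter). For compound 4 the estimated value is 25000 nM, with an expected range of 7000 nM to 90000 nM.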

Compound 4, half-maximal inhibitory concentration: 1830 nM
Compound 4: middle estimate off by 14-fold (1.14 log units), on the high side; measured number outside the range, below it.
By their numbers in this assay, from the lowest: compound 4; then compound 1; then compound 2; then compound 3.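

In this assay, among these compounds, this place on the saturated chain carbon bound to an amide-type nitrogen proves far more sensitive than the earlier compounds showed, with a 330-fold lower number from compound 3 to compound 4 (2.52 log units; beyond the scatter) and a 30-fold lower number from compound 2 to compound 4 (1.47 log units; beyond the scatter) for 3-fluoro-4-methoxyphenyl. The methoxy alone does not set the value, since there is still a 9.3-fold lower number from compound 1 to compound 4 (0.97 log units; beyond the scatter) when fluoro replaces methyl on an aromatic carbon. No available data explain these differences. The compounds shown leave open whether fluoro has this effect without the methoxy, and whether an ethoxy or a dimethylamino group in place of that methoxy would preserve the activity of compound 4.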